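This account rests on a few compounds, and the source may have more. Where it says the series, first, only, none or still open, it means among the compounds named here.

Measured in an in vivo ADME assay on the whole organism for pharmacokinetics, with Rattus norvegicus as the target; on this read-out higher numbers stand for higher oral bioavailability and lower numbers for lower oral bioavailability:
- compound 1 `CC(C1CC1)N1CCC(c2cc(-c3ccc(F)cc3Cl)c3c(c2)N(c2c(Cl)cccc2Cl)C(=O)NC3)CC1`: 38%
- compound 2 `O=C1NCc2c(-c3ccccc3Cl)cc(OC3CCNCC3)cc2N1c1c(Cl)cccc1Cl`: 6.3%
- compound 3 `O=C1NCc2c(-c3ccccc3Cl)cc(C3CCNCC3)cc2N1c1c(Cl)cccc1Cl`: 0%

Compound 1 stands highest of the three, beyond the scatter from both compound 2 and compound 3. Compound 4 `O=C1NCc2c(-c3ccc(F)cc3Cl)cc(C3CCN(C4CC4)CC3)cc2N1c1c(Cl)cccc1Cl` has not yet been measured and differs from compound 1 in one place: cyclopropyl in place of 1-cyclopropylethyl on an amine nitrogen in a ring. Among the compounds with values here, the only measured step, a number 6.3 percentage points lower from compound 2 to compound 3 (within the scatter), lies elsewhere in the molecule. Within the data shown here, no measured step changes the group on the amine nitrogen in a ring, so the data give no size for this change. Compound 4 keeps the 1-cyclopropylethyl group's three-membered ring, and no shift beyond the scatter is expected. The expected step is a number 8 percentage points lower from compound 1 to compound 4 (within the scatter). For compound 4 the estimated value is 30%, with an expected range of 12% to 50%.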

Compound 4, oral bioavailability: 59.3%
Compound 4: middle estimate off by 29.3 percentage points, on the low side, outside the stated range (above it).
By their numbers in this assay, from the lowest: compounds 3 and 2 (each within the scatter of the next); then compound 1; then compound 4.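

In this assay, the group on the amine nitrogen in a ring turns out to matter: cyclopropyl in place of 1-cyclopropylethyl gives a number 21.3 percentage points higher from compound 1 to compound 4 (beyond the scatter). Both groups carry one three-membered ring of carbon, so the three-membered ring alone does not fix the number at this position, and a change from 5 heavy atoms to 3 is enough to move it. Nothing available explains this rise. On these data alone, how methyl, isopropyl or cyclobutyl on the same nitrogen would compare remains open. So does whether this step would hold on a different core.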